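Swapping the Group on the Ring Nitrogen Before Measurement

The compounds below may be only part of what the source reports. "The series", "measured", "known", "first", "only" and "open" are said of these compounds alone.

Of the compounds shown here, three sharing one core have been tested in a functional assay on HeLa cells (Homo sapiens) for antiproliferative activity, read by CCK-8 assay, with a stated time of 72 h, tested at 2 uM; on this read-out higher numbers stand for a stronger effect at the one concentration tested and lower numbers for a weaker effect. Compound 1 `Nc1ccccc1NC(=O)c1ccc(CSC(=S)N2CCN(Cc3ccccn3)CC2)cc1` gives 14.2%, compound 2 `CCN(Cc1ccncc1)C(=S)SCc1ccc(C(=O)Nc2ccccc2N)cc1` gives 63.5%, and compound 3 `Nc1ccccc1NC(=O)c1ccc(CSC(=S)N2CCN(Cc3ccncc3)CC2)cc1` gives 59.5%. Compound 3 therefore stands second highest of the three numbers: its value and that of compound 2 lie within the scatter of each other, while compound 1 lies well below it. Among the compounds with values here, the only step between measured compounds that differ in a single place is a number 45.3 percentage points higher from compound 1 to compound 3 (beyond the scatter), which shows that what sits on the amine nitrogen in a ring can move the read-out a great deal.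

Compound 4 `Nc1ccccc1NC(=O)c1ccc(CSC(=S)N2CCN(c3ccc(F)cc3)CC2)cc1` differs from compound 3 at that same place: 4-fluorophenyl in place of (pyridin-4-yl)methyl on an amine nitrogen in a ring. Within the data shown here, no measured step covers this particular change, so its direction is uncertain; the step from compound 1 to compound 3 only shows that this site is sensitive. A moderate fall is expected, giving a number 19.5 percentage points lower from compound 3 to compound 4 (beyond the scatter). Compound 4 is estimated at 40%, with a range from 15% to 70%.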

Compound 4, a percentage reported as inhibition, at one concentration (the size of the read-out at that concentration, not a potency): 60.8%
Beside the measured number, compound 4's estimate is 20.8 percentage points below it; the measured number falls inside the stated range.
By their numbers in this assay, from the lowest: compound 1; then compounds 3, 4 and 2 (each within the scatter of the next).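

In this assay, replacing (pyridin-4-yl)methyl with 4-fluorophenyl on the ring nitrogen gives a number 1.3 percentage points higher from compound 3 to compound 4 (within the scatter), so this site accepts a ring of carbon only as well as a ring with a hetero atom, and a pyridine nitrogen is not required for this level of effect. The other step, a number 46.6 percentage points higher from compound 1 to compound 4 (beyond the scatter), leaves compound 1 with its (pyridin-2-yl)methyl group as the one low compound among these three, which differ only at this site. No supporting data here explain why that group stands apart.

On these data alone, it remains open whether a methyl group, a carboxylic acid or a longer chain on this ring nitrogen would keep the effect. A reading at one concentration is also not a potency, so compounds 3 and 4 might still separate at other concentrations.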